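Chain Length of the Hydroxamate Tail in Two Related Cores

The source may hold more compounds than are shown below. What is called first, only, known or untested is meant among the compounds shown, and "the series" means these compounds.

Measured compounds:
Compound 1, `Nc1ncnc2c1c(-c1cnc3[nH]ccc3c1)nn2CCCCCCCCC(=O)NO`, gives 7470 nM in a functional assay on HeLa cells (Homo sapiens) for inhibition, read by MTT assay, with a stated time of 72 h; on this read-out lower numbers stand for stronger inhibition and higher numbers for weaker inhibition.
Compound 2, `Nc1ncnc2c1c(-c1cnc3[nH]ccc3c1)nn2CCCCCC(=O)NO`, in this assay reaches only the limit > 150000 nM, which is a limit of the assay rather than a number.
Compound 3, `Nc1nc2cc(-c3nn(CCCCCC(=O)NO)c4ncnc(N)c34)ccc2o1`, gives 15400 nM in this assay.

Compound 1 and compound 2 share one core and differ in the tail: 3-(hydroxycarbamoyl)propyl in place of hydroxycarbamoyl on a saturated chain carbon, five bonds along the chain from an aromatic nitrogen. That change produced an at least 20-fold lower number from compound 2 to compound 1 (1.30 log units; beyond the scatter), a step whose lower edge is set by the limit of > 150000 nM in this assay, at which 1 of the 3 values shown sits. Compound 3 carries a second core; the difference between the two cores is not broken down here. Among the two numbers shown, compound 3 stands highest, its nearest neighbour being compound 1.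

Compound 4, `Nc1nc2cc(-c3nn(CCCCCCCCC(=O)NO)c4ncnc(N)c34)ccc2o1`, has not yet been measured in this assay. It is compound 3 with the same change applied: 3-(hydroxycarbamoyl)propyl in place of hydroxycarbamoyl on a saturated chain carbon, five bonds along the chain from an aromatic nitrogen. The place of the change is the same in both pairs, so it is the same change rather than merely the same kind.

Among the compounds with values here, the expectation for compound 4 rests on the only measured instance of this change, the step from compound 2 to compound 1, an at least 20-fold lower number from compound 2 to compound 1 (1.30 log units; beyond the scatter), which is large; since compound 3 already gives a number rather than a limit, the step for compound 4 is estimated as a 10-fold lower number from compound 3 to compound 4 (1.01 log units; beyond the scatter). Compound 4 is therefore expected to give about 1500 nM, with a range estimated from 300 nM to 7000 nM.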

Compound 4, half-maximal inhibitory concentration: 10200 nM
Compound 4: middle estimate off by 6.8-fold (0.83 log units), on the low side; measured number outside the range, above it.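

In this assay, the change from hydroxycarbamoyl to 3-(hydroxycarbamoyl)propyl does not carry over in size from the core of compound 2 to the core of compound 3: the same change on two cores in this assay, an at least 20-fold lower number (1.30 log units; beyond the scatter) from compound 2 to compound 1 and a 1.5-fold lower number (0.18 log units; within the scatter) from compound 3 to compound 4, at least 13-fold (1.12 log units) apart, beyond the scatter of two such steps

On the second core the change gives a 1.5-fold lower number from compound 3 to compound 4 (0.18 log units; within the scatter), and with the longer tail in place the two cores give values that lie within the scatter of each other, with a 1.4-fold higher number from compound 1 to compound 4 (0.14 log units; within the scatter).

Compound 2 gives only > 150000 nM, which is a limit of the assay and not a number, so the step on its core has no exact size, and two pairs do not show which part of the cores decides the difference or how the change would read on a third core.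

As far as these compounds go, what stays open is how the numbers in this assay run across tail lengths between those of compound 3 and compound 4, and whether a longer chain than that of compound 4 would separate the two cores. From the compounds shown here alone, it is also open how either core would read with a carboxylic acid in place of hydroxycarbamoyl at the end of the chain.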